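Benzimidazole-acetic acid thioethers: bromo to methoxycarbonyl swap

This account rests on a few compounds, and the source may have more. Where it says the series, first, only, none or still open, it means among the compounds named here.

Measured so far in an assay on HEK293 cells for displacement of a labelled ligand from prostaglandin D2 receptor 2 (Homo sapiens); on this read-out lower numbers stand for stronger inhibition and higher numbers for weaker inhibition:
- compound 1, `O=C(O)Cn1c(SCc2cccc(Br)c2)nc2ccccc21`: 370 nM
- compound 2, `O=C(O)Cn1c(SCc2ccccc2Br)nc2ccccc21`: 580 nM
- compound 3, `COC(=O)c1cccc(CSc2nc3ccccc3n2CC(=O)O)c1`: 450 nM

All three share one core and differ only in the substituent on the benzylic ring. Compound 1 and compound 2 carry the same atoms joined differently: 2-bromophenyl in place of 3-bromophenyl on a saturated chain carbon bound to a sulfur. The step of a 1.6-fold higher number from compound 1 to compound 2 (0.20 log units; within the scatter) is within the scatter, so the two numbers cannot be told apart. Compound 1 and compound 3 differ by methoxycarbonyl in place of bromo on an aromatic carbon, and the step of a 1.2-fold higher number from compound 1 to compound 3 (0.09 log units; within the scatter) is likewise within the scatter. Compound 2 and compound 3 have not been compared as a step; their values simply lie close together.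

Compound 4, `COC(=O)c1ccccc1CSc1nc2ccccc2n1CC(=O)O`, has not yet been measured. It differs from compound 2 by methoxycarbonyl in place of bromo on an aromatic carbon. Among the compounds with values here, this is the same kind of change as the one from compound 1 to compound 3, but the place is not the same: in compound 3 the methoxycarbonyl sits meta to a large group, in compound 4 ortho to a large group. Within the data shown here, only the one earlier example of this change exists among the measured compounds, and it moved the number by a 1.2-fold higher number from compound 1 to compound 3 (0.09 log units; within the scatter).

For compound 4 a step of about a 1.2-fold higher number from compound 2 to compound 4 (0.07 log units; within the scatter) in this assay is expected, because the earlier example gave a 1.2-fold higher number from compound 1 to compound 3 (0.09 log units; within the scatter) and the starting point is compound 2 at 580 nM. Compound 4 is therefore estimated at 680 nM, with a likely span from 300 nM to 1500 nM; the different place of the group widens this span.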

Compound 4, half-maximal inhibitory concentration: 520 nM
Beside the measured number, compound 4's estimate is 1.3-fold (0.12 log units) above it; the measured number falls inside the stated range.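

In this assay replacing bromo with methoxycarbonyl on the core of compound 2 gives a 1.1-fold lower number from compound 2 to compound 4 (0.05 log units; within the scatter) and leaves the two numbers indistinguishable, even though the entering group brings more heavy atoms and two hydrogen-bond acceptors. Set beside the earlier example of the same change, the new step does not differ from it: the same change on two cores in this assay, a 1.2-fold higher number (0.09 log units; within the scatter) from compound 1 to compound 3 and a 1.1-fold lower number (0.05 log units; within the scatter) from compound 2 to compound 4, 1.4-fold (0.13 log units) apart, within the scatter of two such steps. Within the data shown here, the change therefore reads the same in both pairs, with methoxycarbonyl and bromo indistinguishable on each core, but that agreement rests on only two pairs whose steps both lie within the scatter, so it shows no transferable gain or loss and says nothing about cores beyond those of compound 1 and compound 2.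

The compounds shown leave open whether a group such as a carboxylic acid, an amine or a longer chain, in place of methoxycarbonyl on the same aromatic carbon, would produce a step that stands clear of the scatter. They also leave open how any of these substituted compounds compares with one carrying only hydrogen at that carbon, so the contribution of bromo or methoxycarbonyl themselves remains unmeasured in this set.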